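The source may hold more compounds than are shown below. What is called first, only, known or untested is meant among the compounds shown, and "the series" means these compounds.

Of the compounds shown here, three of one family have been tested in a functional assay on HCT-116 cells (Homo sapiens) for antiproliferative activity, read by MTT assay, with a stated time of 72 h (on this read-out higher numbers stand for weaker inhibition and lower numbers for stronger inhibition), and a fourth is still to be measured. Compound 1 `O=S1(=O)C=Cc2ccc(Nc3ccc(C(F)(F)F)cc3)cc21` and compound 3 `O=S1(=O)C=Cc2cccc(Nc3ccc(C(F)(F)F)cc3)c21` are built from the same atoms joined differently; the difference between the two cores is not broken down here. In this assay compound 1 gives 1340 nM, and compound 3 gives 1440 nM, two numbers that lie within the scatter of each other, so nothing separates them.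

Compound 2 `O=S1(=O)C=Cc2ccc(Nc3ccc(Cl)cc3)cc21` shares the core of compound 1 but carries a different group on its outer ring. The change is chloro in place of trifluoromethyl on an aromatic carbon. In this assay compound 2 gives 4440 nM, which is a 3.3-fold higher number from compound 1 to compound 2 (0.52 log units; beyond the scatter): the chloro compound inhibits growth less strongly than its trifluoromethyl parent.

Compound 4 `O=S1(=O)C=Cc2cccc(Nc3ccc(Cl)cc3)c21` stands to compound 3 as compound 2 stands to compound 1: the change is chloro in place of trifluoromethyl on an aromatic carbon, the same change at the same kind of place. Because the step of a 3.3-fold higher number from compound 1 to compound 2 (0.52 log units; beyond the scatter) was seen once on the other core, a step of similar size is expected here, with the caution that it rests on a single pair. For compound 4 the expected step is a 3.2-fold higher number from compound 3 to compound 4 (0.50 log units; beyond the scatter). Compound 4 is therefore estimated at 4600 nM in this assay, most likely between 2000 nM and 10500 nM.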

Compound 4, half-maximal inhibitory concentration: 260 nM
Compound 4: the middle estimate sits 18-fold (1.25 log units) above what was measured; measured number below the stated range.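

In this assay, putting chloro in place of trifluoromethyl on the other core gives a 5.5-fold lower number from compound 3 to compound 4 (0.74 log units; beyond the scatter), so here the chloro compound inhibits growth more strongly than its trifluoromethyl parent, the opposite direction to the first pair. What this shows is that the effect of this swap depends on the core that carries it, and a step measured on one core cannot safely be carried over to the other in this series. It does not show why the two cores part ways, and with one pair on each core it cannot say how general the reversal is, but the two steps clearly disagree: the same change on two cores in this assay, a 3.3-fold higher number (0.52 log units; beyond the scatter) from compound 1 to compound 2 and a 5.5-fold lower number (0.74 log units; beyond the scatter) from compound 3 to compound 4, 18-fold (1.26 log units) apart, beyond the scatter of two such steps.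

The compounds shown carry only chloro and trifluoromethyl on the outer ring, so it stays open whether a fluoro, methyl, methoxy or nitrile group in that place would also behave differently on the two cores. Going by these compounds, it also stays open whether the result for compound 4, at 260 nM, would hold in other cell lines or with an oxygen in place of the linking amine.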